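Pyrrolidine to 4-methylpiperidine on the aniline ring

A few compounds are considered here, and "the series" means these few. Any claim that something is new, unique, unknown or untested is made for them only; others in the source may bear on it.

The series shares one core, a chloropyrimidine carrying a propanamide-bearing aryl ether and an aniline whose amino substituent is varied. Compound 1 `CCC(=O)Nc1cccc(Oc2nc(Nc3ccc(N4CCN(C)CC4)cc3)ncc2Cl)c1` carries 4-methylpiperazin-1-yl and in an assay on isolated protein for inhibition of NUAK family SNF1-like kinase 2 (Homo sapiens), read by ADP-Glo, with a stated time of 60 min, tested at 10 uM, in the presence of a further agent that is not named here (a lower number here means less inhibition, a higher number more inhibition at the concentration tested (going by the name of the read-out)), compound 1 gives 82.6%. Compound 2 `CCC(=O)Nc1cccc(Oc2nc(Nc3ccc(N(CC)CC)cc3)ncc2Cl)c1` carries diethylamino, and in this assay compound 2 gives 21.2%. Going by the values given here, the only one-point step measured, a number 61.4 percentage points lower from compound 1 to compound 2 (beyond the scatter), shows that replacing the methylpiperazine with an acyclic dialkylamine costs most of the inhibition. Compound 3 `CCC(=O)Nc1cccc(Oc2nc(Nc3ccc(N4CCCC4)cc3)ncc2Cl)c1` carries pyrrolidin-1-yl and in this assay compound 3 is reported as "not active" (no number reported), so no single number is available for it and its standing can only be read as the low end of the series, alongside compound 2.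

Compound 4 `CCC(=O)Nc1cccc(Oc2nc(Nc3ccc(N4CCC(C)CC4)cc3)ncc2Cl)c1` differs from compound 3 by 4-methylpiperidin-1-yl in place of pyrrolidin-1-yl on an aromatic carbon. Among the compounds with values here, no measured step bears directly on this exchange. The step from compound 1 to compound 2 shows that a saturated amine without the second ring nitrogen sits low in this assay, and compound 3 fits that picture. For compound 4 the expectation is therefore a small or no step beyond the scatter from the low standing of compound 3, with a value in this assay estimated at 15%, ranging from 0% to 40%.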

Compound 4, a percentage reported as inhibition, at one concentration (the size of the read-out at that concentration, not a potency): 24.8%
Beside the measured number, compound 4's estimate is 9.8 percentage points below it; measured number inside the range.
By their numbers in this assay, from the lowest: compounds 2 and 4 (each within the scatter of the next); then compound 1.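

In this assay, the exchange of 4-methylpiperazin-1-yl for 4-methylpiperidin-1-yl gives a number 57.8 percentage points lower from compound 1 to compound 4 (beyond the scatter); the six-membered ring and its methyl group are both kept, so these two features alone do not retain the inhibition seen with compound 1, and within this pair the loss goes with a ring carbon taking the place of the methyl-bearing ring nitrogen. Closing the amine into a methylated ring does not separate the new compound from the acyclic one, with a number 3.6 percentage points higher from compound 2 to compound 4 (within the scatter), while the step from compound 3 to compound 4 cannot be read, as compound 3 has no number. Nothing available explains the loss of inhibition in compound 2 or compound 4.

Still open, on these data alone, is whether the ring nitrogen must carry a methyl group, a question that piperazin-1-yl or 4-ethylpiperazin-1-yl would address, and whether another ring heteroatom can take its place, as the ring oxygen of morpholin-4-yl would test. These percentages come from a single concentration, so they leave the potency of compound 1 undefined.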